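Second chloro on the core: compound 3 to compound 4

The source may report more compounds than this note shows. Statements on the series, on what has been measured and on what is new or still open speak of the compounds shown alone.

Compound 2 `ClCc1ccccc1Cn1cnc2c(Cl)ncnc21` gives 2450 nM in a functional assay on OVCAR-5 cells (Homo sapiens) for cytotoxicity, read by sulforhodamine B assay, with a stated time of 48 h; on this read-out higher numbers stand for weaker inhibition of growth and lower numbers for stronger inhibition of growth; compound 1 `ClCc1ccccc1Cn1cnc2c(Cl)nc(Cl)nc21` gives 1580 nM. The change between them, (chloro in place of hydrogen on an aromatic carbon), yields a 1.6-fold lower number from compound 2 to compound 1 (0.19 log units; within the scatter). Compound 3 `ClCc1cccc(Cn2cnc3ncnc(Cl)c32)c1` gives 6760 nM and stands highest of the three measured numbers; its core and that of compound 2 hold the same atoms joined differently, and this difference between the two cores is not broken down here. Compound 4 `ClCc1cccc(Cn2cnc3nc(Cl)nc(Cl)c32)c1` carries the same change relative to compound 3, (chloro in place of hydrogen on an aromatic carbon). The step from compound 3 to compound 4 is expected to be a 1.6-fold lower number from compound 3 to compound 4 (0.20 log units; within the scatter), resting on the one earlier measured case because compound 2 to compound 1 gave a 1.6-fold lower number from compound 2 to compound 1 (0.19 log units; within the scatter), a step within the scatter. Compound 4 is therefore estimated at 4300 nM, between 2000 nM and 9500 nM.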

Compound 4, concentration for 50% growth inhibition: 1690 nM
Compound 4: middle estimate off by 2.5-fold (0.41 log units), on the high side; measured number outside the range, below it.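

In this assay the chloro in place of hydrogen on an aromatic carbon gives a 4.0-fold lower number from compound 3 to compound 4 (0.60 log units; beyond the scatter) on the core of compound 3, a step beyond the scatter. Set beside the earlier step on the other core, the two do not separate: the same change on two cores in this assay, a 1.6-fold lower number (0.19 log units; within the scatter) from compound 2 to compound 1 and a 4.0-fold lower number (0.60 log units; beyond the scatter) from compound 3 to compound 4, 2.6-fold (0.41 log units) apart, within the scatter of two such steps. Both steps run the same way, which fits a change that carries between these two cores, but two cases, one of them within the scatter, fix no size for it and say nothing about any further core.

The compounds shown hold only chloro or hydrogen at this place between two ring nitrogen atoms. As far as these compounds go, how an amine, a methoxy group or a fluoro group there would read remains open.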